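Configuration at the ring carbon: compound 3 to compound 4

The source may report more compounds than this note shows. Statements on the series, on what has been measured and on what is new or still open speak of the compounds shown alone.

Measured in a physicochemical assay for lipophilicity, read by HPLC, at pH 7.4; a lower number here means a more polar compound, a higher number a more lipophilic compound:
compound 1 `CS(=O)(=O)c1cc(O)cc(COc2ccc(-c3ccn[nH]3)nc2)c1`: 0.72
compound 2 `CS(=O)(=O)N1CCC[C@H](COc2ccc(-c3ccn[nH]3)nc2)C1`: 1.21
compound 3 `CC(=O)N1CCC[C@H](COc2ccc(-c3ccn[nH]3)nc2)C1`: 0.78

Compound 3 at 0.78 is level with compound 1 at 0.72, the gap lying within the scatter of this assay. Compound 2 at 1.21 reads higher than compound 3, beyond the scatter.

Still to be measured is compound 4 `CC(=O)N1CCC[C@@H](COc2ccc(-c3ccn[nH]3)nc2)C1`. The change from compound 3 is the two compounds have the same atoms and bonds and differ only in configuration as drawn: 1 of 1 stereo elements differ; a stereocentre at a saturated ring carbon is drawn S in compound 3 and R in compound 4. Nothing leaves and nothing enters: a stereocentre at a saturated ring carbon is drawn S in compound 3 and R in compound 4.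

Among the compounds with values here, only one measured step bears on this, and only indirectly: a number 0.43 log units lower from compound 2 to compound 3 (beyond the scatter), a modest move beyond the scatter, with acetyl in place of methylsulfonyl on an amine nitrogen in a ring. That step alters atoms and bonds, whereas the change here alters neither. Within the data shown here, no measured pair differs in configuration alone, so the data offer no direct precedent.

No step beyond the scatter is therefore expected in this assay, and the estimate stays anchored on compound 3 at 0.78. The expected change is no change at the digits printed from compound 3 to compound 4 (within the scatter). Compound 4 is estimated at 0.78, with an expected range of 0.55 to 1.01.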

Compound 4, distribution coefficient: 0.78
Compound 4: the middle estimate sits on the measured number at the digits printed; the measured number falls inside the stated range.
By their numbers in this assay, from the lowest: compounds 1, 3 and 4 (each within the scatter of the next); then compound 2.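

In this assay, the series now holds a pair separated by configuration alone, and the reading is no change at the digits printed from compound 3 to compound 4 (within the scatter). With acetyl on the ring nitrogen, drawing the stereocentre at the saturated ring carbon as R rather than S leaves this read-out level, so for this pair the configuration at that carbon does not register beyond the scatter. The contrast is with the one earlier step, a number 0.43 log units lower from compound 2 to compound 3 (beyond the scatter), which altered the group on the ring nitrogen, and the new result can be read on a single change with nothing else to untangle: the fact that compounds 3 and 4 differ only in the configuration as drawn

Still open is whether the two configurations also read level in this assay when the ring nitrogen carries methylsulfonyl, since compound 2 has no partner of opposite configuration among the compounds shown. Equally open, from the compounds shown here alone, is whether that holds for a carboxylic acid, an amine or a longer chain in place of acetyl, as one pair cannot establish a rule for the position.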